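A few compounds are considered here, and "the series" means these few. Any claim that something is new, unique, unknown or untested is made for them only; others in the source may bear on it.

Measured compounds:
compound 1 `CCOC(=O)c1sc(-c2ccccc2)nc1CO`: > 100000 nM
compound 2 `CCOC(=O)c1sc(-c2ccc(C)cc2)nc1O`: 160 nM

In an assay on HEK293 cells for inhibition of transient receptor potential cation channel subfamily M member 8 (Homo sapiens), read by FLIPR, with stated times of 5 min and 3 min (on this read-out higher numbers stand for weaker inhibition and lower numbers for stronger inhibition), compound 1 gives only a limit, > 100000 nM, which is the limit of > 100000 nM in this assay, at which 1 of the 2 values shown sits, so no number fixes where it stands. In this assay compound 2 gives 160 nM. Compound 3 `CCOC(=O)c1cnc(-c2ccccc2)s1` differs from compound 1 by hydrogen in place of hydroxymethyl on an aromatic carbon. Among the compounds with values here, no measured step covers this change, so compound 3 is expected to stay weak, and the step of an at least 3.3-fold lower number from compound 1 to compound 3 (0.52 log units; beyond the scatter) is expected to lean toward stronger inhibition only modestly, with wide uncertainty. The estimate for compound 3 is 30000 nM, from 3000 nM to 100000 nM.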

Compound 3, half-maximal inhibitory concentration: > 100000 nM
Compound 3 was reported as a limit (the forecaster's own chance of this, stated with the estimate: 55%); middle value at least 3.3-fold (0.52 log units) from the limit.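

No step can be read between compound 1 and compound 3, since both results are limits: the limit of > 100000 nM in this assay, at which 2 of the 3 values shown sit. Going by these compounds, whether hydrogen in place of hydroxymethyl on an aromatic carbon changes inhibition at all stays open.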